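A Carbamoylmethyl Branch Added to Compound 1

The compounds below may be only part of what the source reports. "The series", "measured", "known", "first", "only" and "open" are said of these compounds alone.

Of the compounds shown here, two have so far been tested in a functional assay on the whole organism (Tail, strain ICR) with Mus musculus as the target, in the tail flick test, with a stated time of 60 min, at a dose of 25 umol/kg by the oral route; a lower number here means a weaker effect, a higher number a stronger effect of the compound at the dose given. Compound 1, with the structure `O=C(CN(c1nc(Cl)nc2[nH]cnc12)C1CC1)NCC(=O)OCc1ccccc1`, gives 41.9%. Compound 2, with the structure `C[C@@H](O)[C@H](NC(=O)CN(c1ncnc2c1ncn2C1CCCCO1)C1CC1)C(=O)OCc1ccccc1`, gives 28.4%. Compound 1 therefore holds the higher of the two numbers, and compound 2 stands lower by a gap that reaches beyond the usual scatter. Compound 2 differs from compound 1 in more than one place, so its number tells only where it stands and not what any single change does.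

Compound 3, with the structure `NC(=O)C[C@H](NC(=O)CN(c1nc(Cl)nc2[nH]cnc12)C1CC1)C(=O)OCc1ccccc1`, has not yet been measured in this assay. It differs from compound 1 in a single way: carbamoylmethyl in place of hydrogen on a saturated chain carbon bound to an amide-type nitrogen and a carbonyl carbon. For the measured compounds named here, no measured pair shows exactly this change, so any expectation rests on compound 1 and on the lower standing of compound 2, whose value is 28.4% despite its several differences. The expected step is a number 6.9 percentage points lower from compound 1 to compound 3 (within the scatter), a small decrease that may well stay within the scatter. Compound 3 is accordingly estimated at 35%, in a range from 15% to 55%.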

Compound 3, a percentage reported as activity, at one dose (the size of the read-out at that dose, not a potency): 36.4%
Compound 3: middle estimate off by 1.4 percentage points, on the low side, within the range that was stated.
By their numbers in this assay, from the lowest: compounds 2, 3 and 1 (each within the scatter of the next, the first and the last beyond it).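

For the compounds shown here, compound 3 gives the first comparison here that isolates a single change: carbamoylmethyl in place of hydrogen on a saturated chain carbon bound to an amide-type nitrogen and a carbonyl carbon, and in this assay this amounts to a number 5.5 percentage points lower from compound 1 to compound 3 (within the scatter). At this position, then, the added branch, with its amide group, leaves the read-out indistinguishable from that of the unbranched compound, so the position accepts this group without a change that can be told apart from ordinary repeat variation. No available measurement bears on why this is so.

Going by these compounds alone, this single step describes only one group at one position, so it remains open whether a carboxylic acid, an amine or a longer chain on the same carbon would also leave the read-out within the scatter of compound 1. The comparison also rests on one dose at one time point, which leaves open whether compound 1 and compound 3 would still match at other doses or times, and it gives no measure of potency.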